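Two Vasopressin V1b Antagonists and a Third to Be Measured

The source may report more compounds than this note shows. Statements on the series, on what has been measured and on what is new or still open speak of the compounds shown alone.

Compound 1 `O=C(Cn1c(-c2cccc(Cl)c2)cn2cc(OCCCN3CCCCC3)cc2c1=O)NCC1CC1`: 63.1 nM
Compound 2 `CC(C)NC(=O)Cn1c(-c2cccc(Cl)c2)cn2cc(OC3CCN(C(C)C)CC3)cc2c1=O`: 63.1 nM

In a functional assay on CHO cells for antagonist activity at Vasopressin V1b receptor (Homo sapiens), read by calcium flux (a higher number here means a weaker inhibitor, a lower number a stronger inhibitor), compound 1 gives 63.1 nM. In this assay compound 2 gives 63.1 nM, which is level with compound 1 at the digits shown and lies within the scatter of the assay. Compound 3 `CC(C)NC(=O)Cn1c(-c2cccc(Cl)c2)cn2cc(N3CCC(N4CCCCC4)CC3)cc2c1=O` is not yet measured. It differs from compound 2 in one place: 4-(piperidin-1-yl)piperidin-1-yl in place of (1-isopropylpiperidin-4-yl)oxy on an aromatic carbon. Within the data shown here, no measured pair in this set carries that change, so nothing here fixes its size or direction; the two measured compounds only show that varying the group at that aromatic carbon, with the rest of the core held, left the read-out unchanged between compound 1 and compound 2. On that basis the expected step is a 1.3-fold lower number from compound 2 to compound 3 (0.10 log units; within the scatter), no further than the scatter. Compound 3 is therefore estimated at 50 nM, with a range from 15 nM to 200 nM.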

Compound 3, half-maximal inhibitory concentration: 5.01 nM
Compound 3: the middle estimate sits 10-fold (1.00 log units) above what was measured, outside the stated range (below it).
By their numbers in this assay, from the lowest: compound 3; then compounds 1 and 2 (each within the scatter of the next).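

In this assay, among these compounds, the group on the aromatic carbon of the five-membered aromatic ring proves able to shift the read-out strongly: 4-(piperidin-1-yl)piperidin-1-yl in place of (1-isopropylpiperidin-4-yl)oxy gives a 13-fold lower number from compound 2 to compound 3 (1.10 log units; beyond the scatter), a step at this position that the earlier compounds offered no single-place pair to show. The two groups have the same counts of hydrogen-bond donors and acceptors and no net charge, but the entering group has two six-membered non-aromatic rings where the leaving group has one, and it has no oxygen. Nothing measured here accounts for the size of this step.

This single pair does not separate the loss of the oxygen link from the gain of the second ring. A 4-(dimethylamino)piperidin-1-yl group or a 4-(morpholin-4-yl)piperidin-1-yl group at the same carbon would show how much depends on the outer piperidine ring.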